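Restoring the amide methyl: an estimate for compound 4

The compounds below may be only part of what the source reports. "The series", "measured", "known", "first", "only" and "open" are said of these compounds alone.

Compound 1 `COc1ccc(-c2cccc(C(=O)N(C)C)c2)cc1S(=O)(=O)Nc1cccc(N2CCN(C(=O)c3cccc(C)c3)CC2)c1`: > 10000 nM (a limit of the assay)
Compound 2 `COc1ccc(-c2cccc(C(=O)N(C)CCN(C)C)c2)cc1S(=O)(=O)Nc1cccc(NCCNC(=O)c2cccc(C)c2)c1`: 638 nM
Compound 3 `COc1ccc(-c2cccc(C(=O)NCCN(C)C)c2)cc1S(=O)(=O)Nc1cccc(NCCNC(=O)c2cccc(C)c2)c1`: > 10000 nM (a limit of the assay)

In a functional assay on CHO-RD-HGA16 cells for agonist activity at Orexin/Hypocretin receptor type 1 (Homo sapiens), read by fluorescence and calcium flux, with a stated time of 30 min (on this read-out lower numbers stand for an effect already at smaller amounts and higher numbers for an effect only at larger amounts of compound), compound 3 gives only a limit, > 10000 nM. Compound 1 likewise gives only a limit, > 10000 nM. Among the compounds with values here, compound 2 is the one measured compound with a number, 638 nM, and it differs from compound 3 in one place: an at least 15-fold higher number from compound 2 to compound 3 (1.19 log units; beyond the scatter). Two of the three values sit at the limit of > 10000 nM in this assay, at which 2 of the 3 values shown sit.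

Compound 4 `COc1ccc(-c2cccc(C(=O)N(C)Cc3ccccc3)c2)cc1S(=O)(=O)Nc1cccc(NCCNC(=O)c2cccc(C)c2)c1` carries the change (benzyl(methyl)amino in place of (2-(dimethylamino)ethyl)amino on a carbonyl carbon). Through it the methyl on the amide nitrogen returns, the feature whose removal marked the step from compound 2 to compound 3, while the chain bearing the dimethylamino group gives way to a benzyl group. Within the data shown here, only that one step bears on the change, and it was large. Compound 4 is therefore expected to move toward a measurable value, by about an at least 4.0-fold lower number from compound 3 to compound 4 (0.60 log units; beyond the scatter) in this assay, though the exchanged chain leaves the size uncertain. For compound 4 an estimate of 2500 nM is made, with a range from 500 nM to 10000 nM.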

Compound 4, half-maximal effective concentration: > 10000 nM
Compound 4 ended at the assay's limit; the forecaster's own chance of this, stated with the estimate: 35%; middle value at least 4.0-fold (0.60 log units) from the limit.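

Keeping the methyl on the amide nitrogen did not by itself preserve a measurable response in this assay: with phenyl in place of (dimethylamino)methyl on the saturated chain carbon bound to the amide-type nitrogen, the result is an at least 15-fold higher number from compound 2 to compound 4 (1.19 log units; beyond the scatter). Compound 2 therefore remains the only compound shown with a number, and both single changes from it lead to a large step, the other being an at least 15-fold higher number from compound 2 to compound 3 (1.19 log units; beyond the scatter). Compound 3 and compound 4 both give only limits, so the step between them cannot be read: the limit of > 10000 nM in this assay, at which 3 of the 4 values shown sit.

On these data alone, whether a longer chain bearing the dimethylamino group, or a pyrrolidine or a carboxylic acid at the end of the same chain, would retain a number remains open. The limits also leave open how far compound 3 and compound 4 actually lie from compound 2.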